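A Methyl Added Where the Plain Phenyl Gave Nothing

A few compounds are considered here, and "the series" means these few. Any claim that something is new, unique, unknown or untested is made for them only; others in the source may bear on it.

This series pairs a phenylethynyl arm with a small six-membered core. Compound 1, `CC(C)(C)c1ncc(C#Cc2ccccc2)cn1`, carries a tert-butyl group on that core and, in an assay on HEK293 cells for positive allosteric modulation of metabotropic glutamate receptor 5 (Rattus norvegicus) (a lower number here means that less compound is needed, a higher number that more compound is needed for the effect), gives 247000 nM, a very weak effect. Compound 2, `Cc1ncc(C#Cc2ccccc2)cn1`, swaps the tert-butyl for a methyl and in this assay is reported as "not active" (no number reported), so no number marks where it stands; it is simply the compound for which no effect was seen. The untested compound 3, `Cc1cccc(C#Cc2cnc(C)nc2)c1`, keeps the whole of compound 2 and differs only by methyl in place of hydrogen on an aromatic carbon. For the measured compounds named here, no measured pair shows what such a methyl does here, so the expected step in this assay is uncertain; an effect may appear where compound 2 showed none, but it could just as well stay absent. If a number is obtained, compound 3 is expected to land near 20000 nM, within a wide range from 2000 nM to 200000 nM.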

Compound 3, half-maximal effective concentration: "not active" (no number reported)
No number was reported for compound 3, so the estimate cannot be set against anything.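

Compound 2 and compound 3 are both reported as "not active" in this assay, with no number for either, so no step can be read for the added methyl. Nothing available offers an explanation for this result. From the compounds shown here alone, what that methyl does to the effect, if anything, remains open.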